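Extending the amine chain in a chromene series for sigma-1 binding

The compounds below may be only part of what the source reports. "The series", "measured", "known", "first", "only" and "open" are said of these compounds alone.

Measured so far:
Compound 1 `COc1ccc(CNC(C)c2cc3c(cc2OC)OC(C)(C)C=C3)cc1`: 165 nM
Compound 2 `CCNC(C)c1cc2c(cc1OC)OC(C)(C)C=C2`: 83 nM

The two compounds share one core and differ only in the group on the amine nitrogen. In an assay on cell membranes for displacement of a labelled ligand from Sigma non-opioid intracellular receptor 1 (Cavia porcellus), read by scintillation counting (on this read-out higher numbers stand for weaker inhibition and lower numbers for stronger inhibition), compound 1 gives 165 nM and compound 2 gives 83 nM; the step of a 2.0-fold lower number from compound 1 to compound 2 (0.30 log units; within the scatter) is within the scatter, so neither compound can be called the stronger binder. Going by the values given here, compound 2 stands at the lowest of the two numbers, with compound 1 as its only neighbour.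

Compound 3 `CCCCNC(C)c1cc2c(cc1OC)OC(C)(C)C=C2` has not yet been measured. Its change from compound 2 is ethyl in place of hydrogen on a saturated chain carbon, two bonds along the chain from an amine nitrogen, which reads as ethyl to butyl on the amine. Among the compounds with values here, the only step known, a 2.0-fold lower number from compound 1 to compound 2 (0.30 log units; within the scatter), concerns a different position and a different kind of group, and it stayed within the scatter; no step in this set tells how a longer plain alkyl chain behaves. The expectation for compound 3 in this assay is therefore a step of a 1.5-fold lower number from compound 2 to compound 3 (0.18 log units; within the scatter), no larger than the scatter allows, with an estimated value of 55 nM and a range from 15 nM to 200 nM.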

Compound 3, inhibition constant: 22 nM
The estimate for compound 3 lay 2.5-fold (0.40 log units) above the measured number; the measured number falls inside the stated range.
By their numbers in this assay, from the lowest: compound 3; then compounds 2 and 1 (each within the scatter of the next).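

Lengthening the plain chain on the amine from ethyl to butyl produces the first change in this set that can be read as a real difference: in this assay the step is a 3.8-fold lower number from compound 2 to compound 3 (0.58 log units; beyond the scatter), whereas the change on the amine nitrogen that separated the two earlier compounds stayed within the scatter. Replacing 4-methoxyphenyl with propyl at the saturated chain carbon bound to the amine nitrogen also gives a step beyond the scatter, a 7.5-fold lower number from compound 1 to compound 3 (0.88 log units; beyond the scatter), so compound 3 now stands as the strongest binder of the three, while compound 1 and compound 2 remain indistinguishable from each other. No evidence at hand bears on the reason for these steps.

With only ethyl and butyl as plain chains on the amine, the compounds shown leave open whether a longer chain such as hexyl would extend the step, level it off or reverse it. They also leave open how a branched chain such as isobutyl, or a chain ending in a ring such as cyclohexylmethyl, would compare with butyl in this assay.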